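The source may report more compounds than this note shows. Statements on the series, on what has been measured and on what is new or still open speak of the compounds shown alone.

Compounds measured in a functional assay on SGC-7901 cells (Homo sapiens) for cytotoxicity, read by MTT assay, with a stated time of 48 h; a lower number here means a stronger inhibitor, a higher number a weaker inhibitor:
compound 1 `CC1=NN(C(=O)CSc2ccccc2)[C@@H](c2cc(Br)cc(Br)c2O)C1`: 24100 nM
compound 2 `CCCCSCC(=O)N1N=C(c2cc3ccccc3oc2=O)C[C@@H]1c1ccc(C(F)(F)F)cc1`: 2910 nM
compound 3 `O=C(CSCc1ccco1)N1N=C(c2cc3ccccc3oc2=O)C[C@@H]1c1ccc(C(F)(F)F)cc1`: 9740 nM

Compound 1 gives the highest number of the three; compound 3 sits nearest to it and compound 2 furthest away. Compound 4 `CC1=NN(C(=O)CSc2nc3ccccc3s2)[C@@H](c2cc(Br)cc(Br)c2O)C1` differs from compound 1 by 1,3-benzothiazol-2-yl in place of phenyl on a sulfur. Among the compounds with values here, the one measured step, a 3.3-fold higher number from compound 2 to compound 3 (0.52 log units; beyond the scatter), concerns a different core and a different place, a saturated chain carbon bound to a sulfur, so it bears only loosely on this change. Within the data shown here, no step on the shared core of compound 1 is available. The step of a 1.6-fold lower number from compound 1 to compound 4 (0.21 log units; within the scatter) is therefore expected to be modest, its direction uncertain. For compound 4 in this assay a value of 15000 nM is estimated, within a range of 5000 nM to 60000 nM.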

Compound 4, half-maximal inhibitory concentration: 12300 nM
Compound 4: middle estimate off by 1.2-fold (0.09 log units), on the high side; measured number inside the range.
By their numbers in this assay, from the lowest: compound 2; then compounds 3, 4 and 1 (each within the scatter of the next, the first and the last beyond it).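

In this assay, within the data shown here, the first step on the shared core of compound 1 is a 2.0-fold lower number from compound 1 to compound 4 (0.29 log units; within the scatter). On a sulfur whose other neighbour is a saturated chain carbon, 1,3-benzothiazol-2-yl and phenyl therefore cannot be told apart in this assay, although the entering group adds a five-membered aromatic ring with 2 hetero atoms. No available evidence bears on this result.

Still open, from the compounds shown here alone, is how a pyridin-2-yl group or a carboxylic acid on this sulfur would read on the shared core. The compounds shown also leave open whether the same exchange would read alike on the core of compound 2.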